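Replacing acetyl with chloro in a cytotoxic series

This account rests on a few compounds, and the source may have more. Where it says the series, first, only, none or still open, it means among the compounds named here.

Two compounds have been measured so far in a functional assay on CCRF-CEM cells (Homo sapiens) for cytotoxicity; a higher number here means a weaker inhibitor, a lower number a stronger inhibitor
Compound 1 `O=C(/C=C/C(=O)N1C/C(=C\c2ccc([N+](=O)[O-])cc2)C(=O)/C(=C/c2ccc([N+](=O)[O-])cc2)C1)Nc1ccc(Cl)c(Cl)c1` gives 380 nM
Compound 2 `CC(=O)c1ccc(NC(=O)/C=C/C(=O)N2C/C(=C\c3ccccc3)C(=O)/C(=C/c3ccccc3)C2)cc1` gives 1700 nM

Of the two, compound 2 has the higher number, and compound 1 lies lower by a margin beyond the scatter. These two compounds differ in more than one place, so their gap cannot be assigned to any single change. Compound 3 `O=C(/C=C/C(=O)N1C/C(=C\c2ccccc2)C(=O)/C(=C/c2ccccc2)C1)Nc1ccc(Cl)cc1` follows from compound 2 with chloro in place of acetyl on an aromatic carbon, para to a large group.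

Going by the values given here, no two measured compounds differ in one place only, so the data offer no direct precedent for this change. The expectation therefore starts from compound 2 at 1700 nM and stays close to it. Compound 1 at 380 nM also carries chloro but differs in other places too, which makes it only a loose guide. A small step towards a lower number is expected in this assay and it may not exceed the scatter. The expected size is a 1.4-fold lower number from compound 2 to compound 3 (0.15 log units; within the scatter) by this estimate. For compound 3 the estimated value is 1200 nM with an expected range from 450 nM to 3200 nM in these cells.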

Compound 3, half-maximal inhibitory concentration: 840 nM
Compound 3: middle estimate off by 1.4-fold (0.15 log units), on the high side, and the stated range covers the measured number.
By their numbers in this assay, from the lowest: compound 1; then compound 3; then compound 2.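

Going by these compounds alone, compound 3 provides the first comparison that differs in one place only: in this assay, exchanging acetyl for chloro on the aromatic carbon para to a large group gives a 2.0-fold lower number from compound 2 to compound 3 (0.31 log units; beyond the scatter), a modest step on the shared core that lies beyond the scatter. It shows that this position is not indifferent to the group it carries, and that the number does not rise when 3 heavy atoms and 1 hydrogen-bond acceptor leave and a single chlorine enters. No measurement on these compounds bears on why the number falls.

A single pair cannot separate the loss of the acetyl carbonyl from the arrival of chlorine, and it does not show how far the 4-chlorophenyl result extends to other groups at this position, such as an amine, a carboxylic acid or a methoxy group. On these data alone, whether the same exchange would give a step of similar size on a core bearing other substituents also remains open.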